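Fluoro for chloro in a low-inhibition pair

The source may hold more compounds than are shown below. What is called first, only, known or untested is meant among the compounds shown, and "the series" means these compounds.

Compound 1 `O=C1NC(=S)/C(=C/c2ccc(Cl)cc2)S1` gives 16.1%
Compound 2 `O=C1NC(=S)/C(=C/c2cccc(F)c2)S1` gives 19.8%

In a functional assay on HEp-2 cells (Homo sapiens) for cytotoxicity, read by MTT assay, with a stated time of 72 h, tested at 5 ug/mL (on this read-out lower numbers stand for less inhibition of growth and higher numbers for more inhibition of growth at the one concentration tested), compound 1 stands level with compound 2, since their two values lie within the usual scatter of each other. Neither can be ranked above the other.

Compound 3 `O=C1NC(=S)/C(=C/c2ccc(F)cc2)S1` has not yet been measured. Its difference from compound 1 is fluoro in place of chloro on an aromatic carbon and amounts to fluoro in place of chloro on an aromatic carbon of a six-membered aromatic ring of carbon only, para to a group of 8 heavy atoms.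

For the measured compounds named here, no measured pair differs in one place, so the data do not show the size of any single change in this assay directly. Going by the values given here, the only guide is the level set by compound 1 at 16.1% and compound 2 at 19.8% in the same assay. A step beyond the scatter is therefore not expected, in either direction.

The expected result is a number 2.9 percentage points higher from compound 1 to compound 3 (within the scatter) and would stay within the scatter. For compound 3 the estimate is 19% with an expected range from 8% to 35% in this test.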

Compound 3, percent growth inhibition at one concentration: 20.6%
Compound 3: middle estimate off by 1.6 percentage points, on the low side, within the range that was stated.
By their numbers in this assay, from the lowest: compounds 1, 2 and 3 (each within the scatter of the next).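

In this assay, fluoro in place of chloro on an aromatic carbon of a six-membered aromatic ring of carbon only, para to a group of 8 heavy atoms, gives a number 4.5 percentage points higher from compound 1 to compound 3 (within the scatter). For the compounds shown here, this is the first direct reading of a single change, and it shows that exchanging these two halogens at this position leaves compound 1 and compound 3 level, with no difference that this measurement can separate from ordinary scatter. No measurement of any property of the two groups accompanies this result, so the data offer no account of the level reading.

The compounds shown leave open whether a group of another kind at this position, such as an amine, a carboxylic acid or a longer alkyl chain, would give a step beyond the scatter in this assay. They also leave open whether a change to the shared core, rather than to a substituent on the aromatic ring, would move the reading away from the level set by these compounds.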